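Three Level Compounds and a Fluorinated Newcomer

A few compounds are considered here, and "the series" means these few. Any claim that something is new, unique, unknown or untested is made for them only; others in the source may bear on it.

In a functional assay on A549 cells (Homo sapiens) for cytotoxicity, read by MTT assay, with a stated time of 48 h (a higher number here means a weaker inhibitor, a lower number a stronger inhibitor), compound 1 (`COc1ccc(OC)c(C2=NOC(COc3ccc(-c4nnnn4-c4cc(OC)c(OC)c(OC)c4)cc3N)C2)c1`) gives 1930 nM. Compound 2 (`COc1ccc(C2=NOC(COc3ccc(-c4nnnn4-c4cc(OC)c(OC)c(OC)c4)cc3N)C2)cc1N`) gives 2080 nM, and compound 3 (`COc1ccc(C2=NOC(COc3ccc(-c4nnnn4-c4cc(OC)c(OC)c(OC)c4)cc3N)C2)cc1O`) gives 2130 nM. Compound 3 therefore stands level with the other two, since its number cannot be told apart from theirs.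

Compound 4 (`COc1ccc(F)c(C2=NOC(COc3ccc(-c4nnnn4-c4cc(OC)c(OC)c(OC)c4)cc3N)C2)c1`) keeps the shared core and alters one group, with 2-fluoro-5-methoxyphenyl in place of 3-hydroxy-4-methoxyphenyl on a carbon with a double bond to nitrogen.

All three measured steps bear on this change. Each one alters that same group or a part of it. They are small: a 1.1-fold higher number from compound 1 to compound 2 (0.03 log units; within the scatter), a 1.1-fold higher number from compound 1 to compound 3 (0.04 log units; within the scatter) and a 1.0-fold higher number from compound 2 to compound 3 (0.01 log units; within the scatter), all within the scatter. Of the three groups, the 2,5-dimethoxyphenyl of compound 1 has the name closest to the incoming group, and compound 1 gives 1930 nM. Among the measured compounds shown here, none of the measured compounds carries fluoro, so the data offer no direct test of that group, and the range has to stay wide.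

No change beyond the scatter is expected, and the estimated step is a 1.1-fold lower number from compound 3 to compound 4 (0.03 log units; within the scatter). For compound 4 the estimate is 2000 nM, with an expected range from 800 nM to 5000 nM.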

Compound 4, half-maximal inhibitory concentration: 1510 nM
Estimate against measurement, compound 4: 1.3-fold (0.12 log units) above; low and high end bracket the measured number.
By their numbers in this assay, from the lowest: compounds 4, 1, 2 and 3 (each within the scatter of the next).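

Across the four compounds, the group on the carbon with a double bond to nitrogen has now been changed to one carrying fluoro, and in this assay the number stays level throughout (a 1.4-fold lower number from compound 3 to compound 4 (0.15 log units; within the scatter)) and (a 1.4-fold lower number from compound 2 to compound 4 (0.14 log units; within the scatter)) and (a 1.3-fold lower number from compound 1 to compound 4 (0.11 log units; within the scatter)). Among the compounds shown here, the last of these steps is the simplest, since only fluoro in place of methoxy on an aromatic carbon separates the two compounds, and it gives the first direct reading for a fluoro group at this position. The step from compound 3 also shows that the number stays within the scatter when 3-hydroxy-4-methoxyphenyl, with its hydrogen-bond donor, gives way to 2-fluoro-5-methoxyphenyl, which has none, though nothing measured here explains why the change leaves the number level.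

The compounds shown leave open whether a chloro, a nitrile or a trifluoromethyl in place of the fluoro would also stay level. They also leave open whether a carboxylic acid or an amine on a longer chain at this phenyl would move the number beyond the scatter.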